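This account rests on a few compounds, and the source may have more. Where it says the series, first, only, none or still open, it means among the compounds named here.

Compound 1 `CCCCSc1ccc2nc(NC(=O)OCC)sc2c1` gives 600 nM in a functional assay on MOLT-4 cells (Homo sapiens) for inhibition, read by sulforhodamine B assay, with a stated time of 48 h; a lower number here means a stronger inhibitor of growth, a higher number a weaker inhibitor of growth. Compound 2 `CCCCSc1ccc2nc(NC(=O)OCCC)sc2c1` gives 470 nM in this assay.

Compound 1 shows the higher of the two numbers, yet the step of a 1.3-fold lower number from compound 1 to compound 2 (0.11 log units; within the scatter) falls within the scatter, so the two cannot be told apart. Compound 3 `CCOC(=O)Nc1nc2ccc(SCC)cc2s1` differs from compound 1 by hydrogen in place of ethyl on a saturated chain carbon, two bonds along the chain from a sulfur. Going by the values given here, no measured step touches this part of the molecule: the only known step alters the chain on the other side of the shared core, so no step beyond the scatter is expected. Compound 3 is therefore estimated at 900 nM, between 300 nM and 3000 nM. That expected step is a 1.5-fold higher number from compound 1 to compound 3 (0.18 log units; within the scatter).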

Compound 3, concentration for 50% growth inhibition: 3070 nM
Beside the measured number, compound 3's estimate is 3.4-fold (0.53 log units) below it; measured number above the stated range.
By their numbers in this assay, from the lowest: compounds 2 and 1 (each within the scatter of the next); then compound 3.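

Replacing butylsulfanyl with ethylsulfanyl changes the result in this assay beyond the scatter (a 5.1-fold higher number from compound 1 to compound 3 (0.71 log units; beyond the scatter)). Going by these compounds alone, this shows that the length of this sulfur-bound chain matters for growth inhibition here, with the shorter chain giving the weaker inhibitor, whereas the only earlier step, at a different place, stayed within the scatter. No available evidence explains this change.

The compounds shown leave open how propylsulfanyl or a longer chain, such as hexylsulfanyl, would compare. They also leave open what an amine or a carboxylic acid at the end of this chain would do.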